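The source may report more compounds than this note shows. Statements on the series, on what has been measured and on what is new or still open speak of the compounds shown alone.

Of the compounds shown here, three have so far been measured in a functional assay on A549 cells (Homo sapiens) for antiproliferative activity, read by sulforhodamine B assay, with a stated time of 48 h; on this read-out higher numbers stand for weaker inhibition and lower numbers for stronger inhibition. Compound 1 `COc1cc(C(=O)/C=C\Nc2ccc(-c3nc4cc(OC)c(OC)c(OC)c4s3)cc2C)cc(OC)c1OC` gives 23300 nM. Compound 2 `COc1ccc2nc(-c3ccc(N/C=C\C(=O)c4ccc(OC)c([N+](=O)[O-])c4)c(C)c3)sc2c1` gives 13600 nM in this assay, and compound 3 `COc1cc(C(=O)/C=C\Nc2ccc(-c3nc4cc(OC)c(OC)c(OC)c4s3)cc2)cc([N+](=O)[O-])c1OC` gives 11800 nM. The gaps between compound 1 and each of the other two lie within the usual scatter of repeated measurements, so the three numbers cannot be told apart and compound 1 does not stand out from the group in either direction.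

Compound 4 `COc1ccc(C(=O)/C=C\Nc2ccc(-c3nc4cc(OC)c(OC)c(OC)c4s3)cc2C)cc1F` has not yet been measured in this assay. It differs from compound 1 in one place: 3-fluoro-4-methoxyphenyl in place of 3,4,5-trimethoxyphenyl on a carbonyl carbon. Among the measured compounds no pair differs in just one place, so no measured step shows how a change of this kind moves the read-out. The expectation can rest only on the fact that all three measured numbers sit close together. The step from compound 1 to compound 4 is expected to be modest, possibly not beyond the scatter, with a lean toward a higher number; the expected step is a 1.7-fold higher number from compound 1 to compound 4 (0.23 log units; within the scatter). Compound 4 is therefore expected to give about 40000 nM, within a range from 10000 nM to 150000 nM.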

Compound 4, half-maximal inhibitory concentration: 1690 nM
Compound 4: the middle estimate sits 24-fold (1.37 log units) above what was measured, and the stated range ends above it.
By their numbers in this assay, from the lowest: compound 4; then compounds 3, 2 and 1 (each within the scatter of the next).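

In this assay, putting 3-fluoro-4-methoxyphenyl in place of 3,4,5-trimethoxyphenyl on a carbonyl carbon gives a 14-fold lower number from compound 1 to compound 4 (1.14 log units; beyond the scatter) on an otherwise unchanged molecule. This first single-place comparison shows that the read-out responds strongly to the group on this carbonyl carbon, a step large enough to stand well clear of ordinary measurement scatter. No measurement shown here explains why this swap has such an effect.

The swap removes methoxy groups and adds a fluorine at once, so the compounds shown cannot separate the effect of the loss from that of the gain. As far as these compounds go, a plain phenyl group or a chlorophenyl group on the same carbonyl carbon would help to separate them, and it remains open whether this step would hold on a different core.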